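Series notes: 4-fluorophenyl to 4-nitrophenyl

A few compounds are considered here, and "the series" means these few. Any claim that something is new, unique, unknown or untested is made for them only; others in the source may bear on it.

In a functional assay on MCF7 cells (Homo sapiens) for cytotoxicity, read by MTT assay, with a stated time of 72 h (on this read-out higher numbers stand for weaker inhibition and lower numbers for stronger inhibition), compound 1 (`O=C(N/N=C/c1ccc(F)cc1)Nc1cc2c(Nc3ccc(F)c(Cl)c3)ncnc2cc1O[C@H]1CCOC1`) gives 28200 nM and compound 2 (`COc1cc2ncnc(Nc3ccc(F)c(Cl)c3)c2cc1NC(=O)N/N=C/c1ccc(F)cc1`) gives 35100 nM on the same read-out. Going by the values given here, compound 2 stands level with compound 1, its only measured neighbour. Among the compounds with values here, the one measured step is a 1.2-fold higher number from compound 1 to compound 2 (0.10 log units; within the scatter) with methyl in place of oxolan-3-yl on an oxygen on an aromatic ring.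

Compound 3 (`COc1cc2ncnc(Nc3ccc(F)c(Cl)c3)c2cc1NC(=O)N/N=C/c1ccc([N+](=O)[O-])cc1`) differs from compound 2 as 4-fluorophenyl to 4-nitrophenyl (nitro in place of fluoro on an aromatic carbon), with nitro in place of fluoro on an aromatic carbon. Within the data shown here, no measured step covers this change, and the data hold no pair that varies this group. Among the measured compounds shown here, the only guide is a 1.2-fold higher number from compound 1 to compound 2 (0.10 log units; within the scatter) at another place in the structure, so in this assay no step beyond the scatter is expected in either direction. The estimated step is a 1.1-fold lower number from compound 2 to compound 3 (0.04 log units; within the scatter) and nothing firmer is claimed for it. For compound 3 the estimate is 32000 nM with an expected range from 13000 nM to 75000 nM on this read-out.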

Compound 3, half-maximal inhibitory concentration: 36800 nM
Estimate against measurement, compound 3: 1.2-fold (0.06 log units) below; the range from low to high includes it.
By their numbers in this assay, from the lowest: compounds 1, 2 and 3 (each within the scatter of the next).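

Working notes on the position para to a large group: nitro in place of fluoro on an aromatic carbon is the first change read here, and in this assay it gives a 1.0-fold higher number from compound 2 to compound 3 (0.02 log units; within the scatter). The entering nitro brings 3 heavy atoms and 2 hydrogen-bond acceptors where fluoro had 1 heavy atom and 0 hydrogen-bond acceptors, yet compound 3 stands level with compound 2, so these two groups are not separated on this read-out at a site the earlier pair left untouched. No supporting data bear on why the two groups read alike.

As far as these compounds go, it remains open whether any group at this position can produce a step beyond the scatter, since an amine, a carboxylic acid or a longer chain in place of nitro or fluoro would test the position with a different kind of substituent. Going by these compounds alone, also open is whether nitro in place of fluoro reads the same with oxolan-3-yl instead of methyl on the oxygen, as the series so far shows this change only with methyl.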